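Thiophen-3-yl in Place of 3-Nitrophenyl: Expecting Compound 3

This account rests on a few compounds, and the source may have more. Where it says the series, first, only, none or still open, it means among the compounds named here.

Compound 1 `COc1ccc(C(=O)/C=C/c2ccc(Br)cc2)c2c1C=CC(C)(C)O2` gives only a limit in a functional assay on SK-OV-3 cells (Homo sapiens) for antiproliferative activity, read by MTT assay, with a stated time of 24 h; on this read-out higher numbers stand for weaker inhibition and lower numbers for stronger inhibition: > 10000 nM.
Compound 2 `COc1ccc(C(=O)/C=C/c2cccc([N+](=O)[O-])c2)c2c1C=CC(C)(C)O2` gives 9720 nM in this assay.

Compound 2 thus holds the only actual number shown; the other value is the limit (the limit of > 10000 nM in this assay, at which 1 of the 2 values shown sits). For the measured compounds named here, the step of an at least 1.0-fold lower number from compound 1 to compound 2 (0.01 log units; that floor lies within the scatter) therefore tells only that compound 2 is not weaker than the limit of compound 1.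

Compound 3 `COc1ccc(C(=O)/C=C/c2ccsc2)c2c1C=CC(C)(C)O2` differs from compound 2 by thiophen-3-yl in place of 3-nitrophenyl on a double-bonded chain carbon bound to a double-bonded chain carbon. Going by the values given here, no measured step swaps an aryl group for a five-membered heteroaryl group, so the only guide is that both measured compounds sit at or near the limit of this assay. For compound 3 a step of a 1.0-fold higher number from compound 2 to compound 3 (0.01 log units; within the scatter) is expected, that is, no change beyond the scatter. The estimate for compound 3 in this assay is 10000 nM, with a likely range from 3000 nM to 30000 nM, and a fair chance that only a limit is reported.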

Compound 3, half-maximal inhibitory concentration: > 10000 nM
Compound 3: a limit, no number (the forecaster's own chance of this, stated with the estimate: 50%); the middle value sits exactly at the limit.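

Putting thiophen-3-yl, a five-membered aromatic ring, in place of 3-nitrophenyl gives an at least 1.0-fold higher number from compound 2 to compound 3 (0.01 log units; that floor lies within the scatter), so this change brings no gain in inhibition, and any loss has no readable size. Compound 1 and compound 3 both give only a limit, so the step between them cannot be read. With a third aromatic group at this place, only compound 2 yields an actual number, and the others stop at the edge of what the assay reports: the limit of > 10000 nM in this assay, at which 2 of the 3 values shown sit.

The compounds shown leave open whether a different kind of group at this place, such as an amine or a carboxylic acid, would give clearly stronger inhibition in this assay. As far as these compounds go, how far compound 3 lies beyond its limit also stays unknown.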